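One Phenyl Swap, Two Cores: Estimating Compound 4

A few compounds are considered here, and "the series" means these few. Any claim that something is new, unique, unknown or untested is made for them only; others in the source may bear on it.

The measurements come from a functional assay on the whole organism (strain CD1) with Mus musculus as the target, in the maximal electroshock model, with a stated time of 4 h; a higher number here means that more compound is needed for the effect, a lower number that less compound is needed.
Compound 1, `O=C1NC(c2ccccc2)(c2ccccc2)C(=O)N1CN1CCN(c2cccc(Cl)c2)CC1`, gives 100 mg/kg.
Compound 2, `O=C1NC(c2ccccc2)(c2ccccc2)C(=O)N1CN1CCN(c2ccccc2F)CC1`, gives 30 mg/kg.
Compound 3, `CC(C)C1(C(C)C)NC(=O)N(CN2CCN(c3cccc(Cl)c3)CC2)C1=O`, gives 100 mg/kg.

Compounds 1 and 2 share one core and differ only in the group on the ring nitrogen: 2-fluorophenyl in place of 3-chlorophenyl on an amine nitrogen in a ring. That exchange produced a 3.3-fold lower number from compound 1 to compound 2 (0.52 log units; beyond the scatter), so a smaller dose of compound 2 was enough to protect the animals.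

Compound 3 carries a different core but the same 3-chlorophenyl group as compound 1. The difference between the two cores is not broken down here. In this assay compound 3 sits level with compound 1 at the digits recorded, a gap within the usual scatter, and both stand apart from compound 2.

Compound 4, `CC(C)C1(C(C)C)NC(=O)N(CN2CCN(c3ccccc3F)CC2)C1=O`, is not yet measured. It relates to compound 3 exactly as compound 2 relates to compound 1: 2-fluorophenyl in place of 3-chlorophenyl on an amine nitrogen in a ring. The place where the exchange happens is described in the same words for both pairs, so this is the same change made on a second core.

Among the compounds with values here, because the single earlier instance gave a 3.3-fold lower number from compound 1 to compound 2 (0.52 log units; beyond the scatter), a step of similar size is expected here, a 2.5-fold lower number from compound 3 to compound 4 (0.40 log units; beyond the scatter), though with only one precedent the expected range is kept wide. Compound 4 is therefore estimated at 40 mg/kg, expected to fall between 15 mg/kg and 100 mg/kg.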

Compound 4, minimum effective dose: 100 mg/kg
Compound 4: middle estimate off by 2.5-fold (0.40 log units), on the low side; the range from low to high includes it.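

In this assay, placing 2-fluorophenyl where 3-chlorophenyl stood on the second core gives no change at the digits printed from compound 3 to compound 4 (within the scatter), so the lower dose requirement seen on the first core does not reappear. The change therefore did not carry over with the same effect in this pair of cores: the same change on two cores in this assay, a 3.3-fold lower number (0.52 log units; beyond the scatter) from compound 1 to compound 2 and no change at the digits printed (within the scatter) from compound 3 to compound 4, 3.3-fold (0.52 log units) apart, beyond the scatter of two such steps. Within the data shown here, this shows that the result on one core was not a reliable guide to the result on the other, but with only one pair on each core it does not show which feature of the cores matters, nor how the change would behave on any further core.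

The exchange also alters both the halogen and its place on the phenyl ring, so these compounds cannot separate the two, and a plain phenyl group or a pyridine ring on the same ring nitrogen could help show which of them counts on each core. From the compounds shown here alone, it also remains open whether a core bearing shorter chains than compound 3, such as two methyl groups, would follow compound 1 and compound 2 or compound 3 and compound 4.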